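A Larger Group on the Triple Bond

A few compounds are considered here, and "the series" means these few. Any claim that something is new, unique, unknown or untested is made for them only; others in the source may bear on it.

Of the compounds shown here, three built on one shared core have been tested in a functional assay on BaF3 cells (Mus musculus) for antiproliferative activity; a higher number here means that more compound is needed for the effect, a lower number that less compound is needed. Compound 1 (`CCN1CCN(Cc2ccc(NC(=O)c3ccc(C)c(C#Cc4ccc(NC(C)=O)nc4)c3)cc2C(F)(F)F)CC1`), which carries 6-acetamidopyridin-3-yl on a triple-bonded carbon, gives 2050 nM. Compound 2 (`CCN1CCN(Cc2ccc(NC(=O)c3ccc(C)c(C#Cc4cncnc4)c3)cc2C(F)(F)F)CC1`), with pyrimidin-5-yl in that place, gives 2190 nM, which is a 1.1-fold higher number from compound 1 to compound 2 (0.03 log units; within the scatter). Compound 3 (`CCN1CCN(Cc2ccc(NC(=O)c3ccc(C)c(C#Cc4cnc(N)cn4)c3)cc2C(F)(F)F)CC1`), with 5-aminopyrazin-2-yl there, gives 860 nM, the lowest of the three numbers, with a 2.4-fold lower number from compound 1 to compound 3 (0.38 log units; beyond the scatter) and a 2.5-fold lower number from compound 2 to compound 3 (0.41 log units; beyond the scatter).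

Compound 4 (`CCN1CCN(Cc2ccc(NC(=O)c3ccc(C)c(C#Cc4cnc5[nH]c(C)cc5c4)c3)cc2C(F)(F)F)CC1`) has not yet been measured. Its difference from compound 3 is a group of 10 heavy atoms (8 carbon, 2 nitrogen; one five-membered aromatic ring with 1 hetero atom, one six-membered aromatic ring with 1 hetero atom) in place of a group of 7 heavy atoms (4 carbon, 3 nitrogen; one six-membered aromatic ring with 2 hetero atoms), on a triple-bonded carbon. All three measured steps bear on this change, as each is a swap at the same place, and none of them is larger than modest. None of them brings in a group with a five-membered aromatic ring, however, so they guide the size of the new step only loosely and say little about its direction. A modest change in this assay is therefore expected, leaning only tentatively towards a lower number, and a move the other way cannot be ruled out. The expected step is a 1.7-fold lower number from compound 3 to compound 4 (0.24 log units; within the scatter). Compound 4 is estimated at 500 nM, with an expected range from 100 nM to 2000 nM.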

Compound 4, half-maximal effective concentration: 1000 nM
Compound 4: the middle estimate sits 2.0-fold (0.30 log units) below what was measured, and the stated range covers the measured number.
By their numbers in this assay, from the lowest: compounds 3 and 4 (each within the scatter of the next); then compounds 1 and 2 (each within the scatter of the next).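

In this assay, for the compounds shown here, a group with one five-membered and one six-membered aromatic ring appears on the triple-bonded carbon for the first time, and it gives a 1.2-fold higher number from compound 3 to compound 4 (0.07 log units; within the scatter) against 5-aminopyrazin-2-yl, so these two different groups cannot be told apart here. The new group also shares the lower pair with 5-aminopyrazin-2-yl, since the comparison with pyrimidin-5-yl gives a 2.2-fold lower number from compound 2 to compound 4 (0.34 log units; beyond the scatter) and the comparison with 6-acetamidopyridin-3-yl gives a 2.1-fold lower number from compound 1 to compound 4 (0.31 log units; beyond the scatter) in this series. Heavy-atom count does not track these numbers: the groups of compound 1 and compound 4 have the same count yet lie beyond the scatter of each other, while the groups of compound 3 and compound 4 have different counts and lie within it.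

Nothing among the data shown accounts for why the four groups fall into these two pairs. On these data alone, it also remains open how a phenyl ring carrying a carboxylic acid, or a pyridine bearing a longer amine chain, would compare on the same triple-bonded carbon, and whether any such group would move the number beyond the level of this lower pair.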